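A few compounds are considered here, and "the series" means these few. Any claim that something is new, unique, unknown or untested is made for them only; others in the source may bear on it.

Measured compounds, with their readings in a functional assay on SN12C cells (Homo sapiens) for inhibition, read by sulforhodamine B assay, with a stated time of 48 h, tested at 0.1 uM; on this read-out lower numbers stand for a stronger effect and higher numbers for a weaker effect at the one concentration tested:
compound 1, `O=C(Nc1cccc(-n2cc(-c3ccncc3)c(-c3cc(O)cc(Cl)c3)n2)c1)Nc1ccc(Cl)c(C(F)(F)F)c1`, gives 100%
compound 2, `O=C(Nc1cccc(-n2cc(-c3ccncc3)c(-c3cc(O)cc(Cl)c3)n2)c1)Nc1ccc(Cl)c(Cl)c1`, gives 95%
compound 3, `COc1cc(Cl)cc(-c2nn(-c3cccc(NC(=O)Nc4ccc(Cl)c(C(F)(F)F)c4)c3)cc2-c2ccncc2)c1`, gives 100%

Compound 3 stands level with compound 1 at the digits printed, and together these two are the highest of the three numbers. Its nearest neighbour is compound 1, for which no change at the digits printed from compound 1 to compound 3 (within the scatter). Its furthest is compound 2, and that gap is within the scatter.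

Compound 4, `COc1cc(Cl)cc(-c2nn(-c3cccc(NC(=O)Nc4ccc(Cl)c(Cl)c4)c3)cc2-c2ccncc2)c1`, has not yet been measured. The change from compound 3 is chloro in place of trifluoromethyl on an aromatic carbon.

Among the compounds with values here, the one measured step that bears on this change is the same exchange on the same ring, where a number 5 percentage points lower from compound 1 to compound 2 (within the scatter). That step stayed within the scatter, so for compound 4 no step beyond the scatter is expected in this assay.

Compound 4 is therefore expected to give 96% in this assay, with a range from 85% to 105%. The step from compound 3 is expected to be a number 4 percentage points lower from compound 3 to compound 4 (within the scatter).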

Compound 4, a percentage reported as activity, at one concentration (the size of the read-out at that concentration, not a potency): 100%
Compound 4: the middle estimate sits 4 percentage points below what was measured; the measured number falls inside the stated range.
By their numbers in this assay, from the lowest: compounds 2, 1, 3 and 4 (each within the scatter of the next).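

In this assay, chloro in place of trifluoromethyl now reads on a second core, with no change at the digits printed from compound 3 to compound 4 (within the scatter), so at this position the exchange gives no step beyond the scatter whether the oxygen on the other aryl group carries hydrogen or methyl: the same change on two cores in this assay, a number 5 percentage points lower (within the scatter) from compound 1 to compound 2 and no change at the digits printed (within the scatter) from compound 3 to compound 4, 5 percentage points apart, within the scatter of two such steps. Methyl in place of hydrogen on that oxygen also reads on a second background, the 3,4-dichlorophenyl compounds, with a number 5 percentage points higher from compound 2 to compound 4 (within the scatter): the same change on two cores in this assay, no change at the digits printed (within the scatter) from compound 1 to compound 3 and a number 5 percentage points higher (within the scatter) from compound 2 to compound 4, 5 percentage points apart, within the scatter of two such steps. Neither change therefore gives a step beyond the scatter on either background across these four compounds.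

With every step here within the scatter at the one concentration tested, the compounds shown do not tell whether this position affects the read-out at all. On these data alone, it remains open whether an amine, a carboxylic acid or a nitrile at this position would give a step beyond the scatter.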